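Naphthylmethane series: weak inhibitors, one numeric value

The source may hold more compounds than are shown below. What is called first, only, known or untested is meant among the compounds shown, and "the series" means these compounds.

Compound 1 `COc1ccc(/C(=N/O)c2cccc3ccccc23)c(OC)c1OC` in a functional assay on MCF7 cells (Homo sapiens) for inhibition, read by sulforhodamine B assay, with a stated time of 48 h (a lower number here means a stronger inhibitor, a higher number a weaker inhibitor), gives > 20000 nM, which is a limit of the assay and not a number.
Compound 2 `C=CCC(O)(c1ccc(OC)c(OC)c1OC)c1cccc2ccccc12` in this assay gives > 20000 nM, again a limit.
Within the data shown here, compound 3 `COc1ccc(C(c2ccccc2O)c2cccc3ccccc23)c(OC)c1OC` in this assay gives 16600 nM, the only number measured.

Compound 3 thus stands alone on the numbers: the other two members reach only (the limit of > 20000 nM in this assay, at which 2 of the 3 values shown sit). Among the measured compounds shown here, no step between measured compounds is available, since the three structures differ in more than one place.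

Compound 4 `COc1ccc(C(c2ccc(OCC(=O)O)cc2)c2cccc3ccccc23)c(OC)c1OC` carries 4-(carboxymethoxy)phenyl in place of 2-hydroxyphenyl on a saturated chain carbon bound to two aromatic carbons. Without any measured step to lean on, the expected step of a 1.0-fold higher number from compound 3 to compound 4 (0.01 log units; within the scatter) is none beyond the scatter, with a real chance that only a limit is returned. Compound 4 is estimated at 17000 nM, within 6000 nM to 45000 nM.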

Compound 4, half-maximal inhibitory concentration: > 20000 nM
Compound 4 was reported as a limit; the forecaster's own chance of this, stated with the estimate: 45%; middle value at least 1.1-fold (0.07 log units) from the limit.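

In this assay compound 4 gives > 20000 nM, a limit of the assay and not a number. Among these compounds, replacing 2-hydroxyphenyl with 4-(carboxymethoxy)phenyl on a saturated chain carbon bound to two aromatic carbons is the first single-place change available, and it reads as an at least 1.2-fold higher number from compound 3 to compound 4 (0.08 log units; that floor lies within the scatter), so it gives no sign of a lower number at this position. Most of the series now rests at a single limit: the limit of > 20000 nM in this assay, at which 3 of the 4 values shown sit.

Going by these compounds, the true size of this step stays open. Also open, on these data alone, is whether an amine or a longer chain on this carbon would return a number rather than a limit.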